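The source may report more compounds than this note shows. Statements on the series, on what has been measured and on what is new or still open speak of the compounds shown alone.

Measured so far:
- compound 1 `Cc1ccc(/C=C/C(=O)Nc2nnc(-c3ccc(Br)cc3)s2)cc1`: 1.51 ug/mL
- compound 2 `COc1ccc(-c2nnc(NC(=O)/C=C/c3ccc(C(F)(F)F)cc3)s2)cc1`: 0.69 ug/mL

Both values come from a functional assay on A549 cells (Homo sapiens) for antiproliferative activity, read by MTT assay, with a stated time of 48 h; a lower number here means a stronger inhibitor, a higher number a weaker inhibitor. Compound 2 gives the lowest of the two numbers; compound 1 gives a number that sits beyond the usual scatter above it. Compound 3 `COc1ccc(-c2nnc(NC(=O)/C=C/c3ccc(C)cc3)s2)cc1` differs from compound 2 in one place: methyl in place of trifluoromethyl on an aromatic carbon, on a six-membered aromatic ring of carbon only. Among the measured compounds shown here, no measured pair shows this exact change, so the size of the step is uncertain. Compound 1, which also carries a methyl there, gave the higher number, so a modest step toward a higher number from compound 2 to compound 3 is expected, a 1.7-fold higher number from compound 2 to compound 3 (0.24 log units; within the scatter), possibly within the scatter. Compound 3 is estimated at 1.2 ug/mL, between 0.5 ug/mL and 3 ug/mL.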

Compound 3, half-maximal inhibitory concentration: 0.58 ug/mL
Compound 3: middle estimate off by 2.1-fold (0.32 log units), on the high side, and the stated range covers the measured number.
By their numbers in this assay, from the lowest: compounds 3 and 2 (each within the scatter of the next); then compound 1.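

In this assay, methyl in place of trifluoromethyl on this aromatic carbon gives a 1.2-fold lower number from compound 2 to compound 3 (0.08 log units; within the scatter), so the two groups cannot be told apart at this position. Methoxy in place of bromo, with the methyl kept, gives a 2.6-fold lower number from compound 1 to compound 3 (0.42 log units; beyond the scatter), a modest step that lies beyond the scatter. No measurement at hand gives a reason for either step.

From the compounds shown here alone, whether an amine or a carboxylic acid on this aromatic carbon would keep the number this low remains open. So does whether methoxy in place of bromo gives a similar step alongside trifluoromethyl.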